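A few compounds are considered here, and "the series" means these few. Any claim that something is new, unique, unknown or untested is made for them only; others in the source may bear on it.

Compounds measured in an assay on isolated protein for binding affinity to leukotriene B4 receptor 1 (Homo sapiens), tested at 1 uM; a higher number here means more inhibition at the concentration tested (going by the name of the read-out), a lower number less inhibition: compound 1 `CC(=O)c1ccc(OCCCCC#N)cc1O` gives 0%; compound 2 `CCc1cc(C(C)=O)c(O)cc1OCCCCCCC(C)(C)C#N` gives 30%; compound 3 `CCc1cc(C(C)=O)c(O)cc1OCCCCCCC(C)(C)c1nnn[nH]1` gives 67%.

Compound 3 stands highest of the three numbers, with compound 2 nearest and compound 1 furthest. Going by the values given here, the one step that bears on the next change is a number 37 percentage points higher from compound 2 to compound 3 (beyond the scatter). Compound 4 `CCc1cc(C(C)=O)c(O)cc1OCCCCCn1cncn1` differs from compound 3 by 1H-1,2,4-triazol-1-yl in place of 2-(1H-tetrazol-5-yl)-2-methylpropyl on a saturated chain carbon, five bonds along the chain from an oxygen on an aromatic ring. The group that enters carries no hydrogen-bond donor, while the group that leaves carries one, and the chain grows shorter. Since the gain in this assay from compound 2 to compound 3 followed the arrival of the 1H-tetrazol-5-yl, its removal is expected to cost, giving an expected a number 42 percentage points lower from compound 3 to compound 4 (beyond the scatter). Compound 4 is therefore estimated at 25%, between 5% and 50%.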

Compound 4, a percentage reported as inhibition, at one concentration (the size of the read-out at that concentration, not a potency): 30%
For compound 4 the middle estimate is 5 percentage points below the measured one, within the range that was stated.
By their numbers in this assay, from the lowest: compound 1; then compounds 2 and 4 (each within the scatter of the next); then compound 3.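

In this assay the 1H-1,2,4-triazol-1-yl does not match the 2-(1H-tetrazol-5-yl)-2-methylpropyl at this place (a number 37 percentage points lower from compound 3 to compound 4 (beyond the scatter)). It stands level with the 2-cyano-2-methylpropyl (no change at the digits printed from compound 2 to compound 4 (within the scatter)), so a five-membered aromatic ring with hetero atoms does not by itself carry the higher number here. Nothing measured here explains this difference.

From the compounds shown here alone, it remains open whether the 1H-tetrazol-5-yl would keep its number directly on the chain of compound 4, without the two methyl groups. Going by these compounds, it also remains open whether a carboxylic acid on the longer chain would do the same.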